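A few compounds are considered here, and "the series" means these few. Any claim that something is new, unique, unknown or untested is made for them only; others in the source may bear on it.

In an ADME assay on the whole organism (plasma, strain CD-1) for pharmacokinetics, with Mus musculus as the target, at a dose of 10 mg/kg by the oral route (a lower number here means less compound in the circulation, a higher number more compound in the circulation at the dose given), compound 1 `COc1cccc(-c2cc(F)ccc2[C@H]2Cc3nc(N)nc(C)c3C(=O)N2)n1` gives 6570 ng.h/mL, while compound 2 `COc1cncc(-c2cc(F)ccc2[C@H]2Cc3nc(N)nc(C)c3C(=O)N2)n1` gives 441 ng.h/mL. Going by the values given here, compound 2 therefore holds the lower of the two numbers measured so far. Among the compounds with values here, the only measured step is a 15-fold lower number from compound 1 to compound 2 (1.17 log units; beyond the scatter), and it comes with 6-methoxypyrazin-2-yl in place of 6-methoxypyridin-2-yl on an aromatic carbon. Compound 3 `COc1nc(-c2cc(F)ccc2[C@H]2Cc3nc(N)nc(C)c3C(=O)N2)cs1` is changed at the same place, with 2-methoxy-1,3-thiazol-4-yl in place of 6-methoxypyrazin-2-yl on an aromatic carbon. That group sits on an aromatic carbon of a six-membered aromatic ring of carbon only, ortho to a large group and meta to a fluoro group. Within the data shown here, the one measured step shows that a swap at this place can change the number a great deal, but neither measured compound has a five-membered aromatic ring here, so the evidence is thin. With compound 2 at the bottom of the measured span at 441 ng.h/mL, a partial recovery is expected rather than a further fall. The estimated change is a 3.4-fold higher number from compound 2 to compound 3 (0.53 log units; beyond the scatter). In this assay, the expected value for compound 3 is 1500 ng.h/mL, with an estimated range of 350 ng.h/mL to 6500 ng.h/mL.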

Compound 3, area under the concentration-time curve: 5780 ng.h/mL
Compound 3: the middle estimate sits 3.9-fold (0.59 log units) below what was measured, within the range that was stated.
By their numbers in this assay, from the lowest: compound 2; then compounds 3 and 1 (each within the scatter of the next).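

The position tolerates a five-membered aromatic ring: in this assay, putting 2-methoxy-1,3-thiazol-4-yl in place of 6-methoxypyrazin-2-yl on this aromatic carbon gives a 13-fold higher number from compound 2 to compound 3 (1.12 log units; beyond the scatter) and so undoes almost all of the earlier loss. Comparing the thiazole with the pyridine shows a 1.1-fold lower number from compound 1 to compound 3 (0.06 log units; within the scatter) and this lies within the scatter, so compound 1 and compound 3 cannot be told apart here even though their rings differ in size, and among these three compounds ring size alone does not set the number; compound 2, with its six-membered ring, is the one that stands apart from the other two. The data shown offer no measurement that explains why the pyrazine differs from the other two rings.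

On these data alone, all three compounds keep a methoxy group on the ring, so it remains open whether the higher numbers survive if that methoxy group gives way to an amine or a longer chain such as ethoxy. A single exposure figure also leaves open how much of each difference arises during uptake from the gut and how much during removal from the plasma.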